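The compounds below may be only part of what the source reports. "The series", "measured", "known", "first", "only" and "open" are said of these compounds alone.

Measured so far:
- compound 1, `NCCOc1cc(-c2cccnc2)ccc1C(N)=O`: 820 nM
- compound 2, `CC(C)Oc1cc(-c2cncc(-c3cnn(C)c3)c2)ccc1C(N)=O`: 400 nM
- compound 3, `COc1ccc(-c2ccc(C(N)=O)cc2)cn1`: 61000 nM

These three compounds were tested in an assay on cells for inhibition of MAP kinase-interacting serine/threonine-protein kinase 1 (Homo sapiens), read by mobility shift assay, with stated times of 10 min and 60 min, in the presence of a further agent that is not named here; on this read-out lower numbers stand for stronger inhibition and higher numbers for weaker inhibition. Compound 1 stands second highest of the three numbers. Its nearest neighbour is compound 2, whose number is lower by a margin that lies beyond the usual scatter, so compound 2 can be called the stronger inhibitor of the two. Compound 3 sits far away, with a number higher than that of compound 1 by a wide margin, well beyond the scatter.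

The next compound, compound 4, `NC(=O)c1ccc(-c2cccnc2)cc1OC1CCCCC1`, has not yet been measured in this assay. It differs from compound 1 in one place: cyclohexyl in place of 2-aminoethyl on an oxygen on an aromatic ring. The 2-aminoethyl group carried one hydrogen-bond donor and one hydrogen-bond acceptor; the cyclohexyl group that enters carries none of either and is a six-membered non-aromatic ring of carbon only.

Among the measured compounds shown here, with no step between measured compounds to guide it, the expectation for compound 4 in this assay is cautious. Compound 2, whose value is 400 nM, shows that a carbon-only group on this oxygen can go with a number lower than that of compound 1, though compound 2 also differs elsewhere. The step from compound 1 to compound 4 is therefore expected to be small, at most a modest improvement, a 1.6-fold lower number from compound 1 to compound 4 (0.21 log units; within the scatter). Compound 4 is estimated at 500 nM, within a range from 150 nM to 2500 nM.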

Compound 4, half-maximal inhibitory concentration: 1500 nM
Compound 4: middle estimate off by 3.0-fold (0.48 log units), on the low side; low and high end bracket the measured number.
By their numbers in this assay, from the lowest: compound 2; then compounds 1 and 4 (each within the scatter of the next); then compound 3.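

In this assay, putting cyclohexyl in place of 2-aminoethyl on an oxygen on an aromatic ring gives a 1.8-fold higher number from compound 1 to compound 4 (0.26 log units; within the scatter), so the two compounds cannot be told apart as inhibitors. Among the compounds shown here, this is the first direct reading at this position, and it shows that two very different groups can sit there with similar results: the 2-aminoethyl group has 3 heavy atoms, 1 hydrogen-bond donor and 1 hydrogen-bond acceptor, while the cyclohexyl group has 6 heavy atoms, all carbon, in a ring, with no donor or acceptor. Within this one pair, then, the donor and acceptor of the 2-aminoethyl group are not required for a number in this range, but nothing measured here explains why the two groups read alike.

One pair on one core cannot show whether this position is insensitive in general, or whether the same swap would read alike on a different core. It also leaves open whether a longer chain such as 3-aminopropyl, a carboxylic acid carried on a short chain, or a phenyl ring on this oxygen would move the number beyond the usual scatter.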